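This account rests on a few compounds, and the source may have more. Where it says the series, first, only, none or still open, it means among the compounds named here.

Compound 1 `CCC1(CCCCN2CCC(C)CC2)C(=O)Nc2ccccc21`: in a functional assay on the whole organism (strain Wistar) with Rattus norvegicus as the target, with a stated time of 5 min (a higher number here means that more compound is needed for the effect, a lower number that less compound is needed), compound 1 gives "not determined" (no result reported), that is, no result reported. Compound 2 `CCC1(CCCCN2CCN(c3ccc(F)c(Cl)c3)CC2)C(=O)Nc2ccccc21`: in this assay compound 2 gives > 20 mg/kg, which is a limit of the assay and not a number. Compound 3 `CCC1(CCCCN2CCN(c3cccc(Cl)c3)CC2)C(=O)Nc2ccc(Cl)cc21`: in this assay compound 3 gives > 20 mg/kg, again a limit and not a number.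

Compound 3 thus stands at the limit, as does compound 2, and compound 1 brings no number; the only anchor here is the limit of > 20 mg/kg in this assay, at which 2 of the 3 values shown sit. Within the data shown here, no step between measured compounds is available. Compound 4 `CCC1(CCCCN2CCN(c3cccc(Cl)c3)CC2)C(=O)Nc2c(Cl)cc(Cl)cc21` differs from compound 3 by chloro in place of hydrogen on an aromatic carbon. With compound 3 already at a limit, no direction can be read from the data, and any step is expected to lie within the scatter. Compound 4 is therefore expected to give 20 mg/kg, between 10 mg/kg and 40 mg/kg, a step of a number no higher from compound 3 to compound 4 (the limit leaves the size open).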

Compound 4, minimum effective dose: > 20 mg/kg
Compound 4 was reported as a limit (the forecaster's own chance of this, stated with the estimate: 70%); the middle value sits exactly at the limit.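

Compound 3 and compound 4 both stand at a limit of the assay, not at a number, so no step can be read between them: the limit of > 20 mg/kg in this assay, at which 3 of the 4 values shown sit. The compounds shown leave open whether chloro in place of hydrogen on an aromatic carbon alters the minimum effective dose in this assay.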